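The source may report more compounds than this note shows. Statements on the series, on what has been measured and on what is new or still open speak of the compounds shown alone.

Series notes. The shared core is that of compound 1, `Cc1cc2c(cc1C)C(Cl)=C(/C=N/NC(=O)c1ccccc1)CCC2`, which in a functional assay on IMR-32 cells (Homo sapiens) for inhibition, read by sulforhodamine B assay, with a stated time of 48 h (a higher number here means a weaker inhibitor of growth, a lower number a stronger inhibitor of growth), gives 1800 nM. Compound 2, `Cc1cc2c(cc1C)C(Cl)=C(/C=N/NC(=O)c1cccc(Cl)c1)CCC2`, returns only a limit in this assay, > 100000 nM. Compound 3, `Cc1cc2c(cc1C)C(Cl)=C(/C=N/NC(=O)c1cccc(I)c1)CCC2`, gives 1900 nM in this assay. Of the numbers shown, compound 3 and compound 1 sit together within the scatter; the third value is a limit, (the limit of > 100000 nM in this assay, at which 1 of the 3 values shown sits). The measured steps are these: an at least 55-fold higher number from compound 1 to compound 2 (1.74 log units; beyond the scatter); a 1.1-fold higher number from compound 1 to compound 3 (0.02 log units; within the scatter); an at least 52-fold lower number from compound 2 to compound 3 (1.72 log units; beyond the scatter). A halogen at this place therefore gives either no change beyond the scatter or a loss so large that it runs into the limit.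

Compound 4, `Cc1cc2c(cc1C)C(Cl)=C(/C=N/NC(=O)c1cccc(C(F)(F)F)c1)CCC2`, is not yet measured. It differs from compound 3 in one place: trifluoromethyl in place of iodo on an aromatic carbon. Among the compounds with values here, no measured step exchanges iodo for trifluoromethyl, so the steps that bear on it are from compound 1 to compound 2 and from compound 2 to compound 3, both large, and from compound 1 to compound 3, within the scatter. The expectation for compound 4 is a moderate rise in this assay, a 2.6-fold higher number from compound 3 to compound 4 (0.42 log units; beyond the scatter), with a real chance that only a limit is returned. The estimate for compound 4 in this assay is 5000 nM, from 1200 nM to 100000 nM.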

Compound 4, concentration for 50% growth inhibition: 7800 nM
Beside the measured number, compound 4's estimate is 1.6-fold (0.19 log units) below it; low and high end bracket the measured number.
By their numbers in this assay, from the lowest: compounds 1 and 3 (each within the scatter of the next); then compound 4. At a limit, above all of these: compound 2.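

In this assay, trifluoromethyl on this aromatic carbon is the first group shown to give a modest loss, rather than no change beyond the scatter or a loss that runs into a limit, with a 4.3-fold higher number from compound 1 to compound 4 (0.64 log units; beyond the scatter) and a 4.1-fold higher number from compound 3 to compound 4 (0.61 log units; beyond the scatter). The position therefore no longer reads as all or nothing, and the exchange against chloro gives an at least 12-fold lower number from compound 2 to compound 4 (1.10 log units; beyond the scatter), so trifluoromethyl keeps a measurable inhibition of growth where chloro gives none that can be read as a number. Compound 2, with chloro, stands alone among the four as a limit and not a number: the limit of > 100000 nM in this assay, at which 1 of the 4 values shown sits.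

The compounds shown leave open whether the result for chloro is peculiar to that group or would recur with fluoro or bromo at the same place, and how a methoxy group, an amine or a carboxylic acid would behave there. They also leave open whether these groups would read alike elsewhere on the six-membered aromatic ring, and the values alone give no cause for the differences among hydrogen, chloro, iodo and trifluoromethyl.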